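The source may report more compounds than this note shows. Statements on the series, on what has been measured and on what is new or still open speak of the compounds shown alone.

Compound 1 `CN(C)c1cc2[nH]c(C3CCCCC3)nc2cc1NC(=O)c1cccs1`, compound 2 `CCCCOC(=O)Nc1cc2nc(C3CCCCC3)[nH]c2cc1N(CC)CCN(C)C` and compound 3 `CCCc1ccc(C(=O)Nc2cc3nc(C4CCCCC4)[nH]c3cc2N(CC)CC)cc1` share one core and were set up for an ADME assay on Vero cells (Chlorocebus sabaeus) for cytotoxicity, read by resazurin assay, with a stated time of 3 days; a lower number here means a stronger inhibitor, a higher number a weaker inhibitor. In this assay compound 1 reaches only a limit, > 100 ug/mL. Compound 2 likewise ends at a limit in this assay, > 100 ug/mL. Among the compounds with values here, for compound 3 no result was reported in this assay, "not determined" (no result reported), so compound 3 has no number of its own to stand on; the only guide is the limit of > 100 ug/mL in this assay, at which 2 of the 3 values shown sit. Compound 4 `CCN(CC)c1cc2[nH]c(C3CCCCC3)nc2cc1NC(=O)c1cnccn1` is the next compound to go into this assay. The change from compound 3 is pyrazin-2-yl in place of 4-propylphenyl on a carbonyl carbon. Within the data shown here, since no step between measured compounds exists here, no shift beyond the scatter is expected in this assay. Compound 4 is therefore expected to give about 100 ug/mL, within 40 ug/mL to 250 ug/mL.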

Compound 4, half-maximal inhibitory concentration: > 100 ug/mL
Compound 4: no number, only a limit; the forecaster's own chance of this, stated with the estimate: 70%; the middle value sits exactly at the limit.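

No step can be read between compound 3 and compound 4 in this assay, as compound 3 has no reported result. Compound 4 gives only a limit, > 100 ug/mL. The compounds shown leave open what actual value lies behind any of these results: the limit of > 100 ug/mL in this assay, at which 3 of the 4 values shown sit.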